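A few compounds are considered here, and "the series" means these few. Any claim that something is new, unique, unknown or untested is made for them only; others in the source may bear on it.

Four nucleoside analogues share the same sugar and differ only in the heterocyclic base. Compound 1 `C#C[C@@]1(O)[C@@H](CO)O[C@@H](n2cc(Cl)c3c(N)ncnc32)[C@@H]1O` carries a chloro group and an amino-bearing core; in a functional assay on L1210 cells (Mus musculus) for antiproliferative activity, read by cell counting, with a stated time of 48 h (on this read-out higher numbers stand for weaker inhibition and lower numbers for stronger inhibition), compound 1 gives 14 nM. Compound 2 `C#C[C@@]1(O)[C@@H](CO)O[C@@H](n2cc(Br)c3c(N)ncnc32)[C@@H]1O` is its bromo counterpart, and in this assay compound 2 gives 28 nM. The change between them is bromo in place of chloro on an aromatic carbon and it made a step of a 2.0-fold higher number from compound 1 to compound 2 (0.30 log units; within the scatter). Compound 3 `C#C[C@@]1(O)[C@@H](CO)O[C@@H](n2cc(Cl)c3c(Cl)ccnc32)[C@@H]1O` keeps the chloro group but has a different core; the difference between the two cores is not broken down here. In this assay compound 3 gives 75000 nM, a number far higher than those of compound 1 and compound 2, so the core matters greatly while the halogen hardly did.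

Compound 4 `C#C[C@@]1(O)[C@@H](CO)O[C@@H](n2cc(Br)c3c(Cl)ccnc32)[C@@H]1O` is not yet measured. It relates to compound 3 as compound 2 relates to compound 1: the change is bromo in place of chloro on an aromatic carbon, the same change seen once before, at the same kind of place. On that basis, the step expected in this assay for compound 4 is a 1.5-fold higher number from compound 3 to compound 4 (0.17 log units; within the scatter), resting on the step of a 2.0-fold higher number from compound 1 to compound 2 (0.30 log units; within the scatter), which was within the scatter. Compound 4 is therefore expected to give about 110000 nM, most likely between 35000 nM and 350000 nM, with the caveat that compound 3 75000 nM already sits where weak inhibition may not be resolved.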

Compound 4, half-maximal inhibitory concentration: 30000 nM
Compound 4: the middle estimate sits 3.7-fold (0.56 log units) above what was measured, and the stated range ends above it.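

In this assay, bromo in place of chloro on an aromatic carbon gave a 2.5-fold lower number from compound 3 to compound 4 (0.40 log units; beyond the scatter), a modest step toward stronger inhibition. Set beside the earlier case, the same swap did not carry over unchanged from one core to the other, and the two steps point in opposite directions: the same change on two cores in this assay, a 2.0-fold higher number (0.30 log units; within the scatter) from compound 1 to compound 2 and a 2.5-fold lower number (0.40 log units; beyond the scatter) from compound 3 to compound 4, 5.0-fold (0.70 log units) apart, beyond the scatter of two such steps. Among the compounds shown here, this shows that the step measured on one core was a poor guide to the step on the other in this small series, but it does not show why, and with only one pair on each core it establishes no general rule for either core.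

The compounds shown leave open how other groups on this same aromatic carbon, such as iodo, methyl or a nitrile, would behave, and whether any of them would give matching steps on both cores. For the compounds shown here, they also leave open which feature of the two cores separates the steps, as the cores are compared here only as whole units and no compound shows a single part of one core changed on its own.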